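This account rests on a few compounds, and the source may have more. Where it says the series, first, only, none or still open, it means among the compounds named here.

Measured compounds:
compound 1 `Cc1ccc(-c2cc(Br)ccc2OCc2ccc(F)cc2F)n1-c1cc(C(=O)O)cc(N2CCCC2=O)c1` — 2 nM
compound 2 `Cc1ccc(-c2cc(Cl)ccc2OCc2ccccc2)n1-c1cc(Br)cc(C(=O)O)c1` — 5.01 nM

In an assay on CHO cells for displacement of a labelled ligand from prostaglandin E2 receptor EP1 subtype (Homo sapiens) (a higher number here means a weaker inhibitor, a lower number a stronger inhibitor), compound 1 gives 2 nM, the lowest of the two numbers shown. Compound 2 gives 5.01 nM, a higher number beyond the usual scatter. Compound 3 `CC(=O)Nc1cc(C(=O)O)cc(-n2c(C)ccc2-c2cc(Br)ccc2OCc2ccc(F)cc2F)c1` is not yet measured; it differs from compound 1 in one place: acetamido in place of 2-oxopyrrolidin-1-yl on an aromatic carbon. For the measured compounds named here, no pair of measured compounds separated by this kind of change exists, so its size and direction cannot be read from the data. The expected step is a 2.0-fold higher number from compound 1 to compound 3 (0.30 log units; within the scatter), a small shift toward a higher number, possibly within the scatter. For compound 3 the estimate in this assay is 4 nM, with a range from 1 nM to 15 nM.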

Compound 3, half-maximal inhibitory concentration: 0.398 nM
Compound 3: the middle estimate sits 10-fold (1.00 log units) above what was measured; the measured number lies below the stated range.
By their numbers in this assay, from the lowest: compound 3; then compound 1; then compound 2.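

In this assay, the place meta to a carboxy group accepts an open-chain acetamido in place of the ring of 2-oxopyrrolidin-1-yl, with a 5.0-fold lower number from compound 1 to compound 3 (0.70 log units; beyond the scatter) and no loss of binding. Of these two groups, acetamido gives the lower number on the core of compound 1. No measurement shown accounts for the step.

Ring opening and the amide hydrogen enter together, so N-methylacetamido at this place would be needed to separate them. Also open, going by these compounds, is whether propanamido, with its longer chain, or a plain amine keeps the lower number.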